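A few compounds are considered here, and "the series" means these few. Any claim that something is new, unique, unknown or untested is made for them only; others in the source may bear on it.

The study concerns three compounds built on a shared core. Compound 1 `Fc1ccccc1Cn1cc(CSC(=S)N2CCNCC2)nn1` bears hydrogen on its ring amine nitrogen, while compound 2 `CC(C)(C)OC(=O)N1CCN(C(=S)SCc2cn(Cc3ccc(Cl)cc3)nn2)CC1` bears a tert-butoxycarbonyl group there. In a functional assay on ECa-109 cells (Homo sapiens) for inhibition, read by MTT assay, with a stated time of 72 h (on this read-out higher numbers stand for weaker inhibition and lower numbers for stronger inhibition), compound 1 gives only a limit of the assay, > 128000 nM. In this assay compound 2 likewise gives only a limit, > 128000 nM. Compound 2 therefore stands at the limit together with every other value shown, (the limit of > 128000 nM in this assay, at which 2 of the 2 values shown sit), and no number places it anywhere on the scale. Compound 3 `S=C(SCc1cn(Cc2ccc(Cl)cc2)nn1)N1CCNCC1` has not yet been measured in this assay. It differs from compound 2 in one place: hydrogen in place of tert-butoxycarbonyl on an amine nitrogen in a ring. Among the compounds with values here, no measured step between two compounds exists here, so the size of this change cannot be read from the data. Compound 1, which carries the same hydrogen on that nitrogen, gives only a limit, > 128000 nM. The step from the limit of compound 2 is expected to be a number no higher from compound 2 to compound 3 (the limit leaves the size open), none beyond the scatter. Compound 3 is expected at 128000 nM, within 40000 nM to 300000 nM, most probably again reported only as a limit.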

Compound 3, half-maximal inhibitory concentration: > 128000 nM
Compound 3 ended at the assay's limit; the forecaster's own chance of this, stated with the estimate: 75%; the middle value lies on the limit itself.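

In this assay compound 3 gives only a limit, as do compound 1 and compound 2, so no step among these compounds can be read: the limit of > 128000 nM in this assay, at which 3 of the 3 values shown sit. The compounds shown leave open how large the effect of hydrogen in place of tert-butoxycarbonyl, or of 4-chlorophenyl in place of 2-fluorophenyl, is in this assay.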